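The compounds below may be only part of what the source reports. "The series", "measured", "known", "first", "only" and "open" are said of these compounds alone.

Three compounds built on the shared core have been examined in a physicochemical assay for solubility, read by nephelometry, at pH 2; a higher number here means a more soluble compound, a lower number a less soluble compound. Compound 1 `N#Cc1cnc(NC(=O)CCCOc2cccc(Cl)c2)s1` sits at a limit of the assay rather than a number: in this assay compound 1 gives < 1600 nM, which is the limit of < 1600 nM in this assay, at which 1 of the 3 values shown sits. Compound 2 `Cc1cnc(NC(=O)CCCOc2cccc(C#N)c2)s1` also stops at a limit, and in this assay compound 2 gives < 1100 nM. Going by the values given here, compound 3 `Cc1cnc(NC(=O)NCCOc2ccc(Cl)c(C)c2)s1` is the one with a measured number, and in this assay compound 3 gives 1600 nM. So compound 1 stands at the lower edge of what is reported here, with no step between any two of these compounds available to compare.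

Compound 4 `N#Cc1cnc(NC(=O)CCCOc2ccccc2)s1` is not yet measured. It differs from compound 1 in one place: hydrogen in place of chloro on an aromatic carbon. Among the compounds with values here, no measured step of this kind is at hand, so the expectation rests only on the change itself. The step from compound 1 to compound 4 is expected to be modest, toward more soluble, but possibly no larger than the scatter: an at least 1.5-fold higher number from compound 1 to compound 4 (0.19 log units; that floor lies within the scatter). Compound 4 is therefore estimated to show 2500 nM, within a range from 800 nM to 8000 nM.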

Compound 4, solubility: 1100 nM
Beside the measured number, compound 4's estimate is 2.3-fold (0.36 log units) above it, and the stated range covers the measured number.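

No step from compound 1 to compound 4 can be read, because compound 1 stands at a limit of the assay rather than at a number: the limit of < 1600 nM in this assay, at which 1 of the 4 values shown sits.

The compounds shown leave open how far, and in which direction, the read-out in this assay moves when 3-chlorophenyl gives way to phenyl.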